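The source may report more compounds than this note shows. Statements on the series, on what has been measured and on what is new or still open speak of the compounds shown alone.

In an ADME assay on HEK293 cells (Homo sapiens) for cytotoxicity, read by ATP content, with a stated time of 6 h (a higher number here means that more compound is tolerated, a lower number that less compound is tolerated), compound 1 `CCOCCNc1nc(N)nc2ccn(Cc3ccccn3)c12` gives > 24000 nM as a limit, not a number. Compound 2 `Nc1nc(NCc2ncco2)c2c(ccn2Cc2ccccn2)n1` gives > 24000 nM as a limit too. Compound 3 `Cc1cnc(CNc2nc(N)nc3ccn(Cc4ccccn4)c23)o1` gives > 24000 nM as a limit as well. Compound 3 therefore stands with the other two at the limit of > 24000 nM in this assay, at which 3 of the 3 values shown sit, and has no exact number. Compound 4 `Nc1nc(NCc2nccs2)c2c(ccn2Cc2ccccn2)n1` is still unmeasured and carries 1,3-thiazol-2-yl in place of 5-methyl-1,3-oxazol-2-yl on a saturated chain carbon bound to a nitrogen on an aromatic ring. Within the data shown here, three measured steps bear on this change: a step that the two limits leave unreadable from compound 1 to compound 2, a step that the two limits leave unreadable from compound 1 to compound 3 and a step that the two limits leave unreadable from compound 2 to compound 3. None has a readable size, so no step beyond the usual scatter is expected in this assay in either direction. The estimated step is a step that the limit leaves unreadable from compound 3 to compound 4 in this expectation. Compound 4 is estimated at 30000 nM with an expected range from 18000 nM to 48000 nM for its measurement.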

Compound 4, half-maximal cytotoxic concentration: > 24000 nM
Compound 4: no number, only a limit; the forecaster's own chance of this, stated with the estimate: 90%; the middle value lies beyond the limit too.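

Compound 4 gives > 24000 nM, which is a limit and not a number. No step among compound 1, compound 2, compound 3 and compound 4 can be read, as all share one limit: the limit of > 24000 nM in this assay, at which 4 of the 4 values shown sit.

The compounds shown leave open whether these side chains differ at all in how much compound the cells tolerate.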